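Lengthening the amine chain from compound 2 to compound 3

The source may report more compounds than this note shows. Statements on the series, on what has been measured and on what is new or still open speak of the compounds shown alone.

In an ADME assay on cells (Homo sapiens) for cytotoxicity (on this read-out higher numbers stand for weaker inhibition and lower numbers for stronger inhibition), compound 1 `NCCCNC(=O)CCc1ccc(O)c(O)c1` gives > 100 ug/mL as a limit of the assay. Compound 2 `NCCCCNC(=O)CCc1ccc(O)c(O)c1` gives > 100 ug/mL as a limit too, so it stands at a limit and not at a number. For the measured compounds named here, the series so far shows the limit of > 100 ug/mL in this assay, at which 2 of the 2 values shown sit, and no measured number. Compound 3 `NCCCCCNC(=O)CCc1ccc(O)c(O)c1` carries the next change, aminomethyl in place of amino on a saturated chain carbon, four bonds along the chain from an amide-type nitrogen and in words aminomethyl in place of amino on a saturated chain carbon, four bonds along the chain from an amide-type nitrogen. Going by the values given here, the one measured step bearing on it is the same exchange at three bonds, a step that the two limits leave unreadable from compound 1 to compound 2 and with that as the only guide no step beyond the scatter is expected in this assay in either direction. The estimated change is a step that the limit leaves unreadable from compound 2 to compound 3 with no direction favoured. For compound 3 the expected value is 120 ug/mL within an estimated range of 50 ug/mL to 300 ug/mL. Compound 3 may also end at a further limit.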

Compound 3, half-maximal inhibitory concentration: > 100 ug/mL
Compound 3 was reported as a limit (the forecaster's own chance of this, stated with the estimate: 75%); the middle value lies beyond the limit too.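

In this assay compound 3 gives > 100 ug/mL, a limit of the assay. For the compounds shown here, no step among compound 1, compound 2 and compound 3 can be read: the limit of > 100 ug/mL in this assay, at which 3 of the 3 values shown sit.
Whether this assay gives a measured number for any amine chain length stays open with the compounds shown.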